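Swapping a Benzyl Halogen in a Second Dihydropyrimidine Pair

The source may report more compounds than this note shows. Statements on the series, on what has been measured and on what is new or still open speak of the compounds shown alone.

Three compounds were tested in a functional assay on the whole organism (artery, strain albino) with Rattus norvegicus as the target, with a stated time of 30 min, at a dose of 10 mg/kg by the oral route; a higher number here means more inhibition at the dose given (going by the name of the read-out), a lower number less inhibition. Compound 1 `CC1=C(C(=O)Nc2ccc(F)cc2)C(c2ccc([N+](=O)[O-])cc2)N=C(SCc2ccc(Cl)cc2)N1` gives 6.7%, and compound 2 `CC1=C(C(=O)Nc2ccc(F)cc2)C(c2ccc([N+](=O)[O-])cc2)N=C(SCc2ccc(F)cc2)N1` gives 5.7%. The two differ only by fluoro in place of chloro on an aromatic carbon, a change that produced a number 1 percentage points lower from compound 1 to compound 2 (within the scatter). Compound 3 `CC1=C(C(=O)Nc2ccc(Br)cc2)C(c2ccc(Cl)cc2Cl)N=C(SCc2ccc(Cl)cc2)N1` carries a different core; how that core differs from the core of compound 1 is not broken down here. In this assay compound 3 gives 6.7%, which is level with compound 1 at the digits recorded and within the usual scatter of compound 2.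

Compound 4 `CC1=C(C(=O)Nc2ccc(Br)cc2)C(c2ccc(Cl)cc2Cl)N=C(SCc2ccc(F)cc2)N1` has not yet been measured. It stands to compound 3 as compound 2 stands to compound 1: the change is fluoro in place of chloro on an aromatic carbon, the same change made twice among these compounds. Because the earlier instance gave a number 1 percentage points lower from compound 1 to compound 2 (within the scatter), the step from compound 3 to compound 4 is expected to be small as well, estimated as a number 0.7 percentage points lower from compound 3 to compound 4 (within the scatter). Compound 4 is therefore expected to show about 6% in this assay, with a plausible range from 0% to 15%.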

Compound 4, a percentage reported as inhibition, in the whole organism at one dose (the size of the read-out at that dose, not a potency): 7.7%
Compound 4: middle estimate off by 1.7 percentage points, on the low side; the measured number falls inside the stated range.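

In this assay, the exchange of 4-chlorobenzyl for 4-fluorobenzyl gives a number 1 percentage points higher from compound 3 to compound 4 (within the scatter), so on this second core the change again leaves no mark that stands clear of the usual scatter. Across the two cores, the steps agree in staying small and cannot be told apart: the same change on two cores in this assay, a number 1 percentage points lower (within the scatter) from compound 1 to compound 2 and a number 1 percentage points higher (within the scatter) from compound 3 to compound 4, 2 percentage points apart, within the scatter of two such steps This does not show that the two halogens are interchangeable in general, as the pair of steps covers only two cores and a single oral dose, where the numbers give no clear signal of a change.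

The compounds shown leave open whether a different group at this place, such as a methoxy group, an amine or a carboxylic acid, or a longer chain in place of the benzyl group, would move the number beyond the scatter. For the compounds shown here, they also leave open what each of the differences between the two cores contributes, as no single step here separates them.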